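The source may hold more compounds than are shown below. What is called first, only, known or untested is meant among the compounds shown, and "the series" means these compounds.

In an ADME assay on Vero cells (Chlorocebus sabaeus) for cytotoxicity, read by MTT assay, with a stated time of 72 h (on this read-out lower numbers stand for stronger inhibition and higher numbers for weaker inhibition), compound 1 `O=C(CCN1CCN(c2ccc(C(F)(F)F)cc2)CC1)c1ccc(O)cc1` gives 107000 nM, the higher of the two numbers recorded in the series. Within the data shown here, compound 2 `COc1ccc(C(=O)CCNc2ccc(C(F)(F)F)cc2)cc1` gives 32600 nM in this assay; that number lies beyond the scatter of the value of compound 1, but the two structures differ at more than one place, so no single step is read from the pair.

Compound 3 `O=C(CCN1CCN(c2ccc(F)cc2)CC1)c1ccc(O)cc1` is the unmeasured neighbour of compound 1. The change is fluoro in place of trifluoromethyl on an aromatic carbon: the trifluoromethyl leaves and a single fluorine enters on the six-membered aromatic ring of carbon only. Among the measured compounds shown here, no measured pair shows this change, so there is no measured step to lean on. The expected step in this assay is a 1.1-fold higher number from compound 1 to compound 3 (0.05 log units; within the scatter), judged to stay within the scatter and to lean, if anywhere, toward a higher number. Compound 3 is estimated at 120000 nM, with a range from 50000 nM to 280000 nM.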

Compound 3, half-maximal inhibitory concentration: 50000 nM
For compound 3 the middle estimate is 2.4-fold (0.38 log units) above the measured one, and the stated range covers the measured number.
By their numbers in this assay, from the lowest: compounds 2 and 3 (each within the scatter of the next); then compound 1.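

Among these compounds, the trifluoromethyl position gives the first single-place step: in this assay, fluoro in place of trifluoromethyl on the aromatic carbon gives a 2.1-fold lower number from compound 1 to compound 3 (0.33 log units; beyond the scatter) and keeps the rest of compound 1 unchanged. This shows that the number responds to the group at this place, para to a large group, although the step is modest and rests on one pair. The data shown give no reason for the shift and so it stays an observation about this pair alone.

Still open, going by these compounds, is how a nitrile, an amine or a carboxylic acid at this place would compare with fluoro and trifluoromethyl. Also open, on these data alone, is whether the same change would give a step of similar size and direction on the core of compound 2.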